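Methoxy in place of methyl: from compound 1 to compound 4

The compounds below may be only part of what the source reports. "The series", "measured", "known", "first", "only" and "open" are said of these compounds alone.

Of the compounds shown here, three have been measured in a functional assay on SGC-7901 cells (Homo sapiens) for inhibition, read by MTT assay, with a stated time of 72 h; a higher number here means a weaker inhibitor of growth, a lower number a stronger inhibitor of growth. Compound 1 `COC1=C(C)C(=O)C(CCCCCCCCCCn2cc(C[C@H](O)COCCOC[C@@H](O)Cc3ccc(-c4ccccc4)cc3)nn2)=C(C)C1=O` gives 505 nM and holds the lowest number of the three. Compound 3 `COC1=C(OC)C(=O)C(CCCCCCCCCCCCCCCn2cc(C[C@H](O)COCCOC[C@@H](O)Cc3ccc(-c4ccccc4)cc3)nn2)=C(C)C1=O` gives 2490 nM, a higher number than compound 1 beyond the scatter, and compound 2 `O[C@H](COCCOC[C@@H](O)Cc1cn(Cc2ccc3ccccc3c2)nn1)Cc1ccc(-c2ccccc2)cc1` gives 12100 nM, the highest number of the set and furthest from compound 1. For the measured compounds named here, no pair among the measured compounds differs in only one place, so no single step can be read from them; the structures stand beside their values.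

The next compound, compound 4 `COC1=C(OC)C(=O)C(CCCCCCCCCCn2cc(C[C@H](O)COCCOC[C@@H](O)Cc3ccc(-c4ccccc4)cc3)nn2)=C(C)C1=O`, keeps the whole of compound 1 except for one change on the shared core: methoxy in place of methyl on a double-bonded ring carbon. Going by the values given here, with no measured single step to lean on, the expectation is a small step in this assay, toward a higher number, possibly not beyond the scatter. The estimate for compound 4 is 800 nM, with a range from 300 nM to 2500 nM, which corresponds to an expected step of a 1.6-fold higher number from compound 1 to compound 4 (0.20 log units; within the scatter).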

Compound 4, concentration for 50% growth inhibition: 3800 nM
Compound 4: middle estimate off by 4.8-fold (0.68 log units), on the low side; the measured number lies above the stated range.
By their numbers in this assay, from the lowest: compound 1; then compounds 3 and 4 (each within the scatter of the next); then compound 2.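

In this assay, for the compounds shown here, the change from methyl to methoxy on a double-bonded ring carbon is the first single step that can be read, and it gives a 7.5-fold higher number from compound 1 to compound 4 (0.88 log units; beyond the scatter). This ring carbon is therefore not indifferent to the group it bears: of the two groups compared here, methyl goes with the stronger inhibitor of growth. Nothing on hand bears on the reason for this step, which rests on a single pair.

As far as these compounds go, it remains open how a hydrogen, a hydroxyl, an ethoxy group or an amine at this ring carbon would compare with methyl and methoxy. From the compounds shown here alone, it is also open whether the same step would appear with a longer chain on the shared core.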